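Ring size of the basic amine: pyrrolidine to piperidine

This account rests on a few compounds, and the source may have more. Where it says the series, first, only, none or still open, it means among the compounds named here.

Measured compounds:
Compound 1: `COc1cc2c(Oc3ccc(NC(=O)c4nn(-c5ccccc5C)c(=O)cc4C)cc3F)ccnc2cc1OCCCN1CCCCC1`, 1310 nM
Compound 2: `COc1cc2c(Oc3ccc(NC(=O)c4nn(-c5ccccc5C(F)(F)F)c(=O)cc4C)cc3F)ccnc2cc1OCCCN1CCCC1`, 100 nM

Compound 2 holds the lowest of the two numbers in a functional assay on MKN-45 cells (Homo sapiens) for inhibition, read by MTT assay, with a stated time of 72 h; on this read-out lower numbers stand for stronger inhibition and higher numbers for weaker inhibition; compound 1 gives a number that stands beyond the scatter above it, and the two differ in more than one place, so their values are simply noted side by side. Compound 3, `COc1cc2c(Oc3ccc(NC(=O)c4nn(-c5ccccc5C(F)(F)F)c(=O)cc4C)cc3F)ccnc2cc1OCCCN1CCCCC1`, has not been measured in this assay. Its change from compound 2 is piperidin-1-yl in place of pyrrolidin-1-yl on a saturated chain carbon, three bonds along the chain from an oxygen on an aromatic ring; the rest of the molecule is unchanged. Within the data shown here, no measured pair isolates this change, so there is no direct guide to its size. Compound 3 is expected to stay close to compound 2, with a step of a 1.2-fold higher number from compound 2 to compound 3 (0.08 log units; within the scatter) that is not expected to exceed the scatter in either direction. The estimate for compound 3 in this assay is therefore 120 nM, within a range from 45 nM to 320 nM.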

Compound 3, half-maximal inhibitory concentration: 90 nM
Beside the measured number, compound 3's estimate is 1.3-fold (0.12 log units) above it; low and high end bracket the measured number.
By their numbers in this assay, from the lowest: compounds 3 and 2 (each within the scatter of the next); then compound 1.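

In this assay, piperidin-1-yl in place of pyrrolidin-1-yl on this chain gives a 1.1-fold lower number from compound 2 to compound 3 (0.05 log units; within the scatter), so at this position the assay does not tell the two amine rings apart, at least with trifluoromethyl on the aromatic carbon. Among these compounds, compound 3 also provides the first comparison that differs in one place from compound 1: trifluoromethyl in place of methyl on an aromatic carbon gives a 15-fold lower number from compound 1 to compound 3 (1.16 log units; beyond the scatter), which ties this large difference to that single change. No measurement here accounts for either step.

The compounds shown leave open whether a morpholine or a dimethylamine on this chain, or a shorter chain carrying either amine ring, would stay within the same range. They also leave open whether a chlorine or a methoxy group on that aromatic carbon would match trifluoromethyl.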